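Swapping Fluoro for Chloro on the Pendant Phenyl Ring

A few compounds are considered here, and "the series" means these few. Any claim that something is new, unique, unknown or untested is made for them only; others in the source may bear on it.

Compound 2 `Fc1ccc(-c2cn3ccnc3c(-c3ccc4ncn(C5CCCCC5)c4c3)n2)cc1` carries a 4-fluorophenyl group on the shared core. In a functional assay on T47D cells (Homo sapiens) for inhibition, read by sulforhodamine B assay, with a stated time of 48 h, tested at 10 uM (a higher number here means more inhibition at the concentration tested (going by the name of the read-out), a lower number less inhibition), compound 2 gives 33.3%, the lower of the two numbers recorded so far. For the measured compounds named here, its only neighbour, compound 1 `Brc1cn2ccnc2c(-c2ccc3ncn(C4CCCCC4)c3c2)n1`, bears bromo at the same position and in this assay compound 1 gives 49.7%; the step of a number 16.4 percentage points lower from compound 1 to compound 2 (beyond the scatter) is beyond the scatter and modest.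

Compound 3 `Clc1ccc(-c2cn3ccnc3c(-c3ccc4ncn(C5CCCCC5)c4c3)n2)cc1` differs from compound 2 in one place: chloro in place of fluoro on an aromatic carbon. Going by the values given here, no measured step bears directly on this exchange of one halogen for another; the single step known, from bromo to 4-fluorophenyl, replaces the whole group and offers no guide to what swapping fluoro for chloro does. Compound 3 is therefore expected to stay close to compound 2, with a number 2.7 percentage points higher from compound 2 to compound 3 (within the scatter) estimated to fall within the scatter. The estimate for compound 3 in this assay is 36%, with a range from 20% to 55%.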

Compound 3, a percentage reported as inhibition, at one concentration (the size of the read-out at that concentration, not a potency): 27.6%
Compound 3: the middle estimate sits 8.4 percentage points above what was measured; the measured number falls inside the stated range.
By their numbers in this assay, from the lowest: compounds 3 and 2 (each within the scatter of the next); then compound 1.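

Exchanging fluoro for chloro on the pendant phenyl ring gives, in this assay, a number 5.7 percentage points lower from compound 2 to compound 3 (within the scatter), so the two halogens at this place on the ring cannot be told apart in this read-out. The step of a number 22.1 percentage points lower from compound 1 to compound 3 (beyond the scatter) shows that replacing bromo with an aryl group moves the number beyond the scatter with 4-chlorophenyl as well as with 4-fluorophenyl, so this result does not rest on a single aryl group. Nothing available here accounts for either step.

The compounds shown leave open whether an amine, a methoxy group or a carboxylic acid at this place on the phenyl ring would move the number beyond the scatter. They also leave open whether a phenyl ring carrying no halogen would stay with compound 2 and compound 3.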